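Moving a chlorine on the benzyl thioether of a dihydropyrimidine

A few compounds are considered here, and "the series" means these few. Any claim that something is new, unique, unknown or untested is made for them only; others in the source may bear on it.

The study concerns a set of dihydropyrimidine thioethers tested in a functional assay on the whole organism (artery, strain albino) with Rattus norvegicus as the target, with a stated time of 600 min, at a dose of 10 mg/kg by the oral route; a higher number here means more inhibition at the dose given (going by the name of the read-out), a lower number less inhibition. Compound 1, with the structure `CC1=C(C(=O)Nc2ccc(F)cc2)C(c2ccc([N+](=O)[O-])cc2)N=C(SCc2cccc(Cl)c2)N1`, gives 16.4% in this assay. Compound 2, with the structure `CC1=C(C(=O)Nc2ccc(F)cc2)C(c2ccc([N+](=O)[O-])cc2)N=C(SCc2ccc(Cl)cc2)N1`, is built from compound 1 by the change (4-chlorophenyl in place of 3-chlorophenyl on a saturated chain carbon bound to a sulfur), and in this assay compound 2 gives 28.2%. Among the compounds with values here, the step of a number 11.8 percentage points higher from compound 1 to compound 2 (beyond the scatter) is the only measured instance of this change in the set.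

Compound 3, with the structure `CC1=C(C(=O)Nc2ccc(Br)cc2)C(c2ccc(Cl)cc2Cl)N=C(SCc2cccc(Cl)c2)N1`, shares the dihydropyrimidine thioether motif but carries a different core than compound 1; the difference between the two cores is not broken down here. In this assay compound 3 gives 15.4%, which sits within the scatter of the value of compound 1 and beyond the scatter below the value of compound 2.

Compound 4, with the structure `CC1=C(C(=O)Nc2ccc(Br)cc2)C(c2ccc(Cl)cc2Cl)N=C(SCc2ccc(Cl)cc2)N1`, has not been measured. It relates to compound 3 by the change (4-chlorophenyl in place of 3-chlorophenyl on a saturated chain carbon bound to a sulfur), which is the same change, at the same place, as that between compound 1 and compound 2. Resting on the single precedent of compound 1 to compound 2, whose step is a number 11.8 percentage points higher from compound 1 to compound 2 (beyond the scatter), the account expects a step of about a number 10.6 percentage points higher from compound 3 to compound 4 (beyond the scatter) from compound 3 to compound 4, with added uncertainty because the core is different and only one example is known. Compound 4 is therefore estimated to give about 26% in this assay, with a likely range from 13% to 39%.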

Compound 4, a percentage reported as inhibition, in the whole organism at one dose (the size of the read-out at that dose, not a potency): 30.3%
Compound 4: middle estimate off by 4.3 percentage points, on the low side, and the stated range covers the measured number.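

On the core of compound 3, replacing the 3-chlorobenzyl group with the 4-chlorobenzyl group on the sulfur gives a number 14.9 percentage points higher from compound 3 to compound 4 (beyond the scatter) in this assay, so this second instance of the change points the same way as the first. Set side by side, the two instances do not differ in size, and the change carried over from one core to the other with much the same result: the same change on two cores in this assay, a number 11.8 percentage points higher (beyond the scatter) from compound 1 to compound 2 and a number 14.9 percentage points higher (beyond the scatter) from compound 3 to compound 4, 3.1 percentage points apart, within the scatter of two such steps. This shows agreement on two cores only and at a single oral dose, where the read-out gives the size of the inhibition and not a potency, so it neither establishes a rule for other cores in the series nor explains why the 4-chlorobenzyl compounds give the higher numbers.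

The compounds shown leave open whether the step would persist on a core with other groups in place of those carried here, for instance with a carboxylic acid or an amine on the aromatic ring of the amide. They also leave open what an unsubstituted benzyl, a methoxybenzyl or a longer chain such as phenethyl on the sulfur would give in this assay.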